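A few compounds are considered here, and "the series" means these few. Any claim that something is new, unique, unknown or untested is made for them only; others in the source may bear on it.

Measured so far in a functional assay on HEp-2 cells (Homo sapiens) for inhibition; on this read-out higher numbers stand for weaker inhibition and lower numbers for stronger inhibition:
Compound 1, `CCC(C)C(NC(=O)n1nnc2ccccc21)C(=O)NC(c1ccccc1)c1ccccc1`, gives 55300 nM.
Compound 2, `CCC(C)C(NC(=O)NO)C(=O)NCc1ccccc1`, gives > 100000 nM, which is a limit of the assay and not a number.

Going by the values given here, compound 2 thus stands at the limit (the limit of > 100000 nM in this assay, at which 1 of the 2 values shown sits), with no number of its own, and no step between the two measured compounds is computed, since they differ in more than one place; their two values show only that compound 1 has a number and compound 2 does not. Compound 3, `CCC(C)C(NC(=O)n1nnc2ccccc21)C(=O)NCc1ccccc1`, is not yet measured. Compared with compound 2 it carries a group of 9 heavy atoms (6 carbon, 3 nitrogen; one five-membered aromatic ring with 3 hetero atoms, one six-membered aromatic ring of carbon only) in place of a group of 2 heavy atoms (1 nitrogen, 1 oxygen; no ring), on a carbonyl carbon. Because compound 2 is known only as a limit, the size of the step from compound 2 to compound 3 in this assay cannot be read from the data; compound 1, which shares the group that enters, has a number that is itself weak. Compound 3 is therefore expected to remain weak in this assay, with an estimated value of 80000 nM and a range from 20000 nM to 300000 nM. This estimate corresponds to an expected step of an at least 1.2-fold lower number from compound 2 to compound 3 (0.09 log units; that floor lies within the scatter), with a real chance that only a limit is reported again.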

Compound 3, half-maximal inhibitory concentration: > 100000 nM
Compound 3 was reported as a limit (the forecaster's own chance of this, stated with the estimate: 55%); middle value at least 1.2-fold (0.09 log units) away from the limit.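

With hydroxyamino replaced on the carbonyl carbon by the group with the two aromatic rings, compound 3 still yields no number of its own in this assay, only a limit of the assay, so this change does not bring the compound into the measurable range, and the step from compound 2, which is also a limit, cannot be read. Going by these compounds alone, the new compound also gives the first readable step: hydrogen in place of phenyl on a saturated chain carbon bound to an amide-type nitrogen and an aromatic carbon gives an at least 1.8-fold higher number from compound 1 to compound 3 (0.25 log units; that floor lies within the scatter), so the phenyl is the one difference between a numbered value and a limit, yet no effect of that phenyl is established. The limit now holds most of the data in this assay: the limit of > 100000 nM in this assay, at which 2 of the 3 values shown sit.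

On these data alone, how far compound 2 and compound 3 lie past the limit stays unknown, so the true size of both changes remains open. The compounds shown also leave open what an amine or a carboxylic acid would give in place of the group on the carbonyl carbon.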